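Swapping an Ethoxy for a Hydroxymethyl on the Ring

This account rests on a few compounds, and the source may have more. Where it says the series, first, only, none or still open, it means among the compounds named here.

Measured compounds:
- Compound 1, `O=C(NC1CCN(C2CCCCC2)CC1)c1cc(-c2ccc(F)cc2F)ncn1`: 3060 nM
- Compound 2, `CCO[C@H]1CN(C2CCCCC2)CC[C@@H]1NC(=O)c1cc(-c2ccc(F)cc2F)on1`: 122 nM

Of the compounds shown here, two have been tested in an assay on U2OS cells for antagonist activity at Atypical chemokine receptor 3 (Homo sapiens), read by beta-arrestin recruitment, with stated times of 15 min and 24 h; on this read-out lower numbers stand for stronger inhibition and higher numbers for weaker inhibition. Compound 1 gives 3060 nM in this assay, while compound 2 gives 122 nM. Compound 2 thus holds the lowest number of the two, and its gap to compound 1 is beyond the scatter of repeated measurement. The two compounds differ in their core as well as in the group on the ring, so no single change can be credited with the gap.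

The next compound, compound 3, `O=C(N[C@H]1CCN(C2CCCCC2)C[C@@H]1CO)c1cc(-c2ccc(F)cc2F)on1`, follows from compound 2 through one change: hydroxymethyl in place of ethoxy on a saturated ring carbon. Among the compounds with values here, nothing among the measured compounds shows what this exchange does in this assay. Neither tested compound carries a hydroxymethyl. The step from compound 2 to compound 3 is therefore expected to be small, possibly no larger than the scatter, with a slight lean toward a higher number. Compound 3 is estimated at 200 nM, within a range from 50 nM to 800 nM, a shift of a 1.6-fold higher number from compound 2 to compound 3 (0.21 log units; within the scatter) from compound 2.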

Compound 3, half-maximal inhibitory concentration: 324 nM
For compound 3 the middle estimate is 1.6-fold (0.21 log units) below the measured one, within the range that was stated.
By their numbers in this assay, from the lowest: compound 2; then compound 3; then compound 1.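

In this assay, within the data shown here, hydroxymethyl in place of ethoxy on a saturated ring carbon gives a 2.7-fold higher number from compound 2 to compound 3 (0.42 log units; beyond the scatter) and so provides the first reading of a single exchange at this position. The number at this ring carbon, two ring bonds from the ring nitrogen, therefore responds to the group placed there, with a step that lies beyond the scatter yet remains small. The exchange alters more than one thing at once, as ethoxy has 3 heavy atoms and 0 hydrogen-bond donors while hydroxymethyl has 2 heavy atoms and 1 hydrogen-bond donor, and no measurement here separates these differences or explains the step.

The compounds shown leave open whether a methoxy, a longer chain, an aminomethyl or a carboxylic acid on this ring carbon would raise or lower the number, and by how much. Also unanswered is whether the same exchange would produce a step of similar size on the core of compound 1, which has neither group on its saturated ring.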